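The compounds below may be only part of what the source reports. "The series", "measured", "known", "first", "only" and "open" are said of these compounds alone.

The measured compounds:
Compound 1, `COc1cc(-c2nc3cc(Cl)ccc3[nH]2)cc(I)c1O`, gives 1610 nM in an assay for inhibition of Alpha amylase (Homo sapiens), with a stated time of 10 min; on this read-out lower numbers stand for stronger inhibition and higher numbers for weaker inhibition.
Compound 2, `Oc1c(Br)cc(Cl)cc1-c1nc2cc(Cl)ccc2[nH]1`, gives 2860 nM.
Compound 3, `COc1cc(-c2nc3cc([N+](=O)[O-])ccc3[nH]2)cc(I)c1O`, gives 1720 nM.

Compound 1 and compound 3 share one core and differ in a single place: nitro in place of chloro on an aromatic carbon. This change made a 1.1-fold higher number from compound 1 to compound 3 (0.03 log units; within the scatter). Compound 2 carries a different core; the difference between the two cores is not broken down here. The gaps between compound 2 and each of the other two compounds are within the scatter, so the three numbers cannot be told apart with confidence.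

Compound 4, `O=[N+]([O-])c1ccc2[nH]c(-c3cc(Cl)cc(Br)c3O)nc2c1`, has not yet been measured in this assay. It arises from compound 2 by nitro in place of chloro on an aromatic carbon, the same change at the same place as between compound 1 and compound 3. Going by the values given here, because the one measured instance of this change gave a 1.1-fold higher number from compound 1 to compound 3 (0.03 log units; within the scatter), compound 4 is expected to stay close to compound 2, with an expected step of a 1.1-fold higher number from compound 2 to compound 4 (0.03 log units; within the scatter). Compound 4 is therefore estimated at 3100 nM, in a likely range from 1500 nM to 6500 nM.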

Compound 4, half-maximal inhibitory concentration: 2870 nM
Compound 4: the middle estimate sits 1.1-fold (0.03 log units) above what was measured; the measured number falls inside the stated range.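

On the core of compound 2, nitro in place of chloro on an aromatic carbon gives a 1.0-fold higher number from compound 2 to compound 4 (0.00 log units; within the scatter) in this assay. Set beside the earlier step, the change carries from one core to the other with no difference that can be told from the scatter: the same change on two cores in this assay, a 1.1-fold higher number (0.03 log units; within the scatter) from compound 1 to compound 3 and a 1.0-fold higher number (0.00 log units; within the scatter) from compound 2 to compound 4, 1.1-fold (0.03 log units) apart, within the scatter of two such steps. Going by these compounds alone, this shows that, on these two cores, compounds with nitro and chloro at this place cannot be told apart in this read-out, but with only two pairs it does not show that the same would hold on other cores, and it does not explain why the two groups read alike.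

The compounds shown leave open whether another group at this place, such as an amine or a carboxylic acid, would shift the number beyond the scatter. A step of that size would be a stricter test of whether a change carries between cores, and none appears among these four compounds.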